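A few compounds are considered here, and "the series" means these few. Any claim that something is new, unique, unknown or untested is made for them only; others in the source may bear on it.

Compound 1 `Clc1nss/c1=N\c1ccc(OCc2ccccc2)cc1`: in a functional assay on A-431 cells (Homo sapiens) for cytotoxicity, read by resazurin assay, with a stated time of 72 h (a higher number here means a weaker inhibitor, a lower number a stronger inhibitor), compound 1 gives > 100000 nM, a limit of the assay rather than a number. Compound 2 `FC(F)(F)Oc1ccc(/N=c2\ssnc2Cl)cc1Br`: in this assay compound 2 gives 100000 nM. Compound 3 `O=S(=O)(Nc1nccs1)c1ccc(/N=c2\ssnc2Cl)cc1`: in this assay compound 3 gives > 100000 nM, again a limit of the assay.

Compound 3 therefore stands at a limit, not at a measured number, one of the two values sitting at the limit of > 100000 nM in this assay, at which 2 of the 3 values shown sit. Compound 4 `O=S(=O)(Nc1ncccn1)c1ccc(/N=c2\ssnc2Cl)cc1` differs from compound 3 by pyrimidin-2-yl in place of 1,3-thiazol-2-yl on a sulfonamide nitrogen. Among the compounds with values here, no step between measured compounds is available to anchor this change. The values shown give no sign of a gain, so compound 4 is expected to stay near that limit, with no step beyond the scatter. The expected step is a number no higher from compound 3 to compound 4 (the limit leaves the size open). The estimate for compound 4 is 100000 nM, between 30000 nM and 300000 nM.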

Compound 4, half-maximal inhibitory concentration: > 100000 nM
Compound 4: no number, only a limit; the forecaster's own chance of this, stated with the estimate: 75%; the middle value lies on the limit itself.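

No step can be read from compound 3 to compound 4, as each gives only a limit: the limit of > 100000 nM in this assay, at which 3 of the 4 values shown sit.

The compounds shown leave open whether pyrimidin-2-yl in place of 1,3-thiazol-2-yl on a sulfonamide nitrogen changes the result at all.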